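Demethylation at the phenol in a pyrazole urea series

A few compounds are considered here, and "the series" means these few. Any claim that something is new, unique, unknown or untested is made for them only; others in the source may bear on it.

Compound 1 `O=C(Nc1cccc(-n2cc(-c3ccncc3)c(-c3ccc(Cl)c(O)c3)n2)c1)Nc1cccc(C(F)(F)F)c1` — > 32500 nM
Compound 2 `COc1cc(-c2nn(-c3cccc(NC(=O)Nc4ccc(Cl)c(Cl)c4)c3)cc2-c2ccncc2)ccc1Cl` — 4480 nM

Of the compounds shown here, two sharing the same core have been measured in a functional assay on MOLT-4 cells (Homo sapiens) for inhibition, read by sulforhodamine B assay, with a stated time of 48 h; a lower number here means a stronger inhibitor of growth, a higher number a weaker inhibitor of growth. Compound 1 gives only a limit there, > 32500 nM, so no number is known for it. Compound 2 gives 4480 nM in this assay. Compound 2 thus holds the only number shown; the other result, that of compound 1, is a limit, as stated in the limit of > 32500 nM in this assay, at which 1 of the 2 values shown sits.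

Compound 3 `O=C(Nc1cccc(-n2cc(-c3ccncc3)c(-c3ccc(Cl)c(O)c3)n2)c1)Nc1ccc(Cl)c(Cl)c1` is the next step. It differs from compound 2 in one place: hydrogen in place of methyl on an oxygen on an aromatic ring. Elsewhere the two are identical, including the 3,4-dichlorophenyl urea. Compound 1 also carries the hydroxy group, but differs from compound 3 in the urea aryl, so its limit cannot be read as a measured step to compound 3.

For the measured compounds named here, no step between measured compounds is known here, so the size of the change can only be estimated. Going by the values given here, the expectation is a loss of activity going a 2.2-fold higher number from compound 2 to compound 3 (0.35 log units; beyond the scatter), beyond the usual scatter, since the only hydroxy analogue, compound 1, gave > 32500 nM. Compound 3 is therefore estimated at 10000 nM, within a range from 3000 nM to 35000 nM.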

Compound 3, concentration for total growth inhibition: > 32500 nM
Compound 3 gave a limit, no number; the forecaster's own chance of this, stated with the estimate: 30%; middle value at least 3.2-fold (0.51 log units) from the limit.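

In this assay, the change from methoxy to hydroxy on the aromatic ring now stands as a clean single change, with the 3,4-dichlorophenyl urea held constant, and it gives an at least 7.2-fold higher number from compound 2 to compound 3 (0.86 log units; beyond the scatter) in this pair. The earlier compounds shown here could not show this, since compound 1 carries the hydroxy group together with a different urea aryl, so its result could not be assigned to the oxygen substituent alone. The step from compound 1 to compound 3 cannot be read, and both of these hydroxy compounds give only a limit, not a number: the limit of > 32500 nM in this assay, at which 2 of the 3 values shown sit.

As far as these compounds go, how far compound 1 and compound 3 actually lie beyond that limit remains open, as does whether the 3-(trifluoromethyl)phenyl urea would perform differently from the 3,4-dichlorophenyl urea with methoxy kept in place. From the compounds shown here alone, it is equally open whether the loss is specific to the hydroxy group or would extend to other groups on that ring position, such as an ethoxy group, an amine or a plain hydrogen.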